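Phenoxy in Place of Bromo in Diacylglycerol Lipase Inhibitors

The source may report more compounds than this note shows. Statements on the series, on what has been measured and on what is new or still open speak of the compounds shown alone.

Compound 1 `O=C(N1CCC=C[C@@H]1COCc1ccccc1)n1cc(-c2ccc([N+](=O)[O-])cc2)nn1` and compound 2 `O=C(N1CCC=C[C@@H]1COCc1ccccc1)n1cc(-c2ccc(Br)cc2)nn1` share one core and differ only in the group on the aromatic ring. In an assay on HEK293 cells for inhibition of diacylglycerol lipase-alpha (Homo sapiens), read by colorimetric assay, with stated times of 30 min, 60 s and 20 min (on this read-out higher numbers stand for weaker inhibition and lower numbers for stronger inhibition), compound 1 gives 15.9 nM, and in this assay compound 2 gives 15.9 nM. The step of no change at the digits printed from compound 1 to compound 2 (within the scatter) shows that bromo in place of nitro on an aromatic carbon leaves the read-out unmoved, so compound 2 stands level with compound 1 at the digits shown. Compound 3 `O=C(N1CCC=C[C@@H]1COCc1ccccc1)n1cc(-c2ccc(Oc3ccccc3)cc2)nn1` carries phenoxy in place of bromo on an aromatic carbon. For the measured compounds named here, the only measured step bearing on this change is no change at the digits printed from compound 1 to compound 2 (within the scatter), within the scatter; it shows that this aromatic carbon accepts two unlike groups equally, but no measured compound carries a group as large as phenoxy there. Compound 3 is expected to shift by about a 1.6-fold higher number from compound 2 to compound 3 (0.20 log units; within the scatter) in this assay, a small step toward weaker inhibition at most. Compound 3 is therefore estimated at 25 nM in this assay, with a range from 6 nM to 100 nM.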

Compound 3, half-maximal inhibitory concentration: 25.1 nM
Estimate against measurement, compound 3: 1.0-fold (0.00 log units) below; the range from low to high includes it.
By their numbers in this assay, from the lowest: compounds 1, 2 and 3 (each within the scatter of the next).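

In this assay, the step of a 1.6-fold higher number from compound 2 to compound 3 (0.20 log units; within the scatter) shows that this aromatic carbon, para to a large group, accepts phenoxy, with 7 heavy atoms and an aromatic ring of its own, in place of bromo, with 1 heavy atom, and the read-out stays within the scatter. The step of a 1.6-fold higher number from compound 1 to compound 3 (0.20 log units; within the scatter) likewise stays within the scatter, so the tolerance seen earlier for nitro and bromo now reaches a far larger group that brings a further ring and a hydrogen-bond acceptor. No measurement is at hand that explains why these three groups read alike.

The compounds shown leave open whether an amine or a carboxylic acid on this aromatic carbon would also leave the read-out within the scatter. Also open, as far as these compounds go, is whether a longer chain ending in a phenyl ring would be accepted here as phenoxy is.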